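Adding fluoro to compound 3: what to expect

A few compounds are considered here, and "the series" means these few. Any claim that something is new, unique, unknown or untested is made for them only; others in the source may bear on it.

Among the measured compounds shown here, compound 3 `O=C1/C(=C/c2ccccc2)CCc2ccc(O)cc21` stands lowest of the three numbers measured so far in a functional assay on RAW264.7 cells (Mus musculus) for inhibition; on this read-out lower numbers stand for stronger inhibition and higher numbers for weaker inhibition: compound 3 gives 710 nM. Nearest to it is compound 2 `O=C1/C(=C/c2cccc(Br)c2)CCc2cc(O)ccc21`, which in this assay gives 1140 nM, a gap within the scatter. Furthest is compound 1 `O=C1/C(=C/c2cccc(Cl)c2)CCc2cc(O)ccc21`, which in this assay gives 1750 nM, a gap beyond the scatter. For the measured compounds named here, the one step between measured compounds that differ in a single place, a 1.5-fold lower number from compound 1 to compound 2 (0.19 log units; within the scatter), is bromo in place of chloro on an aromatic carbon, and it stays within the scatter.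

Compound 4 `O=C1/C(=C/c2ccccc2F)CCc2ccc(O)cc21` differs from compound 3 by fluoro in place of hydrogen on an aromatic carbon, on an aromatic carbon of a six-membered aromatic ring of carbon only, ortho to a large group. Going by the values given here, no measured step trades a hydrogen for a halogen on that ring, and the step of a 1.5-fold lower number from compound 1 to compound 2 (0.19 log units; within the scatter) exchanges one halogen for another on compounds whose core differs from that of compound 3, so it bears on the question only loosely; its small size gives no sign that a halogen on that ring shifts the number far. The expectation in this assay is therefore no step beyond the scatter in either direction. For compound 4 the estimate is 650 nM, with a range from 250 nM to 1700 nM. The expected step of a 1.1-fold lower number from compound 3 to compound 4 (0.04 log units; within the scatter) is accordingly small.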

Compound 4, half-maximal inhibitory concentration: 1350 nM
Estimate against measurement, compound 4: 2.1-fold (0.32 log units) below, and the stated range covers the measured number.
By their numbers in this assay, from the lowest: compounds 3, 2, 4 and 1 (each within the scatter of the next, the first and the last beyond it).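

In this assay, among the compounds shown here, this is the first step that puts a halogen in place of hydrogen on this ring, and it gives a 1.9-fold higher number from compound 3 to compound 4 (0.28 log units; within the scatter). At this place, on an aromatic carbon of a six-membered aromatic ring of carbon only, ortho to a large group, fluoro therefore leaves compound 4 within the scatter of compound 3, and the two cannot be ranked on this read-out; the earlier halogen step, a 1.5-fold lower number from compound 1 to compound 2 (0.19 log units; within the scatter), exchanged one halogen for another on a different core and could not show this. No measurement at hand explains why the number of compound 4 falls where it does, so the result stands as an observation only.

The compounds shown leave open whether a larger substituent at this same place, such as methoxy, trifluoromethyl, an amine or a carboxylic acid, would also stay within the scatter of compound 3 or would move the number beyond it. They also leave open whether chloro or bromo, seen so far only on the core of compound 1, would behave as fluoro does here on the core of compound 3.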